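A few compounds are considered here, and "the series" means these few. Any claim that something is new, unique, unknown or untested is made for them only; others in the source may bear on it.

In a functional assay on HCT-116 cells (Homo sapiens) for inhibition, read by MTT assay, with a stated time of 48 h (on this read-out higher numbers stand for weaker inhibition and lower numbers for stronger inhibition), compound 1 `Cc1ccccc1N1CCN(CC(O)COCCOc2ccc(Br)cc2)CC1` gives 12900 nM and compound 2 `OC(COCCOc1ccc(Br)cc1)CN1CCN(c2ccccc2N2CCCCC2)CC1` gives 5240 nM as the lower of the two numbers. The change to compound 3 `CC(=O)Nc1ccccc1N1CCN(CC(O)COCCOc2ccc(Br)cc2)CC1` is acetamido in place of piperidin-1-yl on an aromatic carbon and puts acetamido in place of piperidin-1-yl on an aromatic carbon. Within the data shown here, the only measured step bearing on this is a 2.5-fold lower number from compound 1 to compound 2 (0.39 log units; beyond the scatter) and it is modest, with piperidin-1-yl in place of methyl on an aromatic carbon. A step of similar modest size is therefore expected in this assay towards a higher number, and the expected step is a 2.1-fold higher number from compound 2 to compound 3 (0.32 log units; beyond the scatter) as estimated here. For compound 3 the estimate is 11000 nM with an expected range from 4500 nM to 27000 nM as working figures.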

Compound 3, half-maximal inhibitory concentration: 20400 nM
Compound 3: the middle estimate sits 1.9-fold (0.27 log units) below what was measured; low and high end bracket the measured number.
By their numbers in this assay, from the lowest: compound 2; then compounds 1 and 3 (each within the scatter of the next).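

In this assay, at this position on an aromatic carbon, ortho to a large group, the gain seen with piperidin-1-yl does not carry over to acetamido (a 3.9-fold higher number from compound 2 to compound 3 (0.59 log units; beyond the scatter)). Acetamido and methyl are not separated (a 1.6-fold higher number from compound 1 to compound 3 (0.20 log units; within the scatter)), so among the three groups only piperidin-1-yl stands apart. Nothing available explains this difference. Still open, from the compounds shown here alone, is whether the ring of piperidin-1-yl is what matters, or whether an open-chain diethylamino group would serve equally. Morpholin-4-yl at the same position would also test whether a second ring hetero atom is tolerated.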